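The source may report more compounds than this note shows. Statements on the series, on what has been measured and on what is new or still open speak of the compounds shown alone.

Working notes on the cinnamoyl sulfonamide series.

Within the data shown here, compound 1 `O=C(/C=C/c1ccccc1)NS(=O)(=O)c1ccccc1` gives 3.5 ug/mL in a functional assay on B16-F10 cells (Mus musculus) for antiproliferative activity, read by ELISA and MTT assay, with a stated time of 48 h (a higher number here means a weaker inhibitor, a lower number a stronger inhibitor), the lowest of the three numbers measured so far. Compound 3 `O=C(/C=C/c1ccccc1)NS(=O)(=O)c1ccc(Br)cc1` gives 3.9 ug/mL, and the step of a 1.1-fold higher number from compound 1 to compound 3 (0.05 log units; within the scatter) lies within the scatter. Compound 2 `Cc1ccc(S(=O)(=O)NC(=O)/C=C/c2ccccc2)cc1` gives 13.8 ug/mL; here the step of a 3.9-fold higher number from compound 1 to compound 2 (0.60 log units; beyond the scatter) is modest but beyond the scatter, as is a 3.5-fold lower number from compound 2 to compound 3 (0.55 log units; beyond the scatter).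

Compound 4 `CN(C)c1ccc(/C=C/C(=O)NS(=O)(=O)c2ccccc2)cc1` is the next compound in line. Relative to compound 1 the change is dimethylamino in place of hydrogen on an aromatic carbon. Among the measured compounds shown here, no measured step touches this place, and no measured step introduces a group of this kind, so the only guide is the spread of the substituent steps seen so far: one within the scatter, one modest and upward. On that basis the step in this assay is expected to be small, with no strong expectation of direction, so compound 4 is estimated at 4.5 ug/mL (range 1.8 ug/mL to 12 ug/mL), meaning an expected step of a 1.3-fold higher number from compound 1 to compound 4 (0.11 log units; within the scatter).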

Compound 4, half-maximal inhibitory concentration: 2.3 ug/mL
Estimate against measurement, compound 4: 2.0-fold (0.29 log units) above; the range from low to high includes it.
By their numbers in this assay, from the lowest: compounds 4, 1 and 3 (each within the scatter of the next); then compound 2.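

Adding dimethylamino to compound 1, para to a large group, leaves the number in this assay close to that of the parent: a 1.5-fold lower number from compound 1 to compound 4 (0.18 log units; within the scatter) stays within the scatter, so no gain or loss can be read from it. Among these compounds, this is the first view of this place, on a different aromatic ring from the one carrying methyl in compound 2 and bromo in compound 3, and it shows that a nitrogen-bearing group of this size can stand here without a step beyond the scatter. No measurement on hand accounts for this result.

Open, as far as these compounds go, is whether a primary amine, a methoxy group or a carboxylic acid at this place would stay equally close to compound 1. Also open, from the compounds shown here alone, is how dimethylamino here would behave with bromo or methyl on the other ring.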